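Swapping a benzylic phenyl for a chloroethyl chain

The source may hold more compounds than are shown below. What is called first, only, known or untested is meant among the compounds shown, and "the series" means these compounds.

Among the compounds with values here, compound 2 `CC(=O)OCC(CCn1cc(C#CCc2ccccc2)c(=O)n(C(=O)c2ccccc2)c1=O)COC(C)=O` is the only compound with a number: in a functional assay on SW-620 cells (Homo sapiens) for antiproliferative activity, read by MTT assay, with a stated time of 72 h (a lower number here means a stronger inhibitor, a higher number a weaker inhibitor), compound 2 gives 36400 nM. Compound 1 `O=c1[nH]c(=O)n(CCC(CO)CO)cc1-c1cccs1` gives only > 100000 nM, a limit of the assay rather than a number. That marks (the limit of > 100000 nM in this assay, at which 1 of the 2 values shown sits). Within the data shown here, no step between two measured compounds is available. Compound 3 `CC(=O)OCC(CCn1cc(C#CCCCCl)c(=O)n(C(=O)c2ccccc2)c1=O)COC(C)=O` differs from compound 2 by 2-chloroethyl in place of phenyl on a saturated chain carbon bound to a triple-bonded carbon. The step from compound 2 to compound 3 is expected to be a 1.5-fold higher number from compound 2 to compound 3 (0.18 log units; within the scatter), leaning toward weaker inhibition, though possibly no larger than the scatter. Compound 3 is therefore estimated at 55000 nM, within 15000 nM to 150000 nM.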

Compound 3, half-maximal inhibitory concentration: > 100000 nM
Compound 3 ended at the assay's limit (the forecaster's own chance of this, stated with the estimate: 35%); middle value at least 1.8-fold (0.25 log units) from the limit.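

At this position, on a saturated chain carbon bound to a triple-bonded carbon, the change is not neutral: 2-chloroethyl in place of phenyl weakens the compound in this assay (an at least 2.7-fold higher number from compound 2 to compound 3 (0.43 log units; beyond the scatter)). Within the data shown here, the phenyl-bearing chain of compound 2 therefore goes with the only measured number here. That step is only a minimum, since compound 3 sits at a limit of the assay: the limit of > 100000 nM in this assay, at which 2 of the 3 values shown sit.

This single pair cannot separate losing the phenyl ring from gaining the chlorine. A plain propyl chain or a cyclohexyl group at this place would be needed to tell them apart.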